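The compounds below may be only part of what the source reports. "The series", "measured", "known", "first", "only" and "open" are said of these compounds alone.

Compound 3 `COc1ccc(OC(C)(C)C2OCC(C/C=C\CCC(=O)O)C(c3cccnc3)O2)cc1` gives 302 nM in a functional assay for inhibition, with Homo sapiens as the target (on this read-out higher numbers stand for weaker binding and lower numbers for tighter binding), the second highest of the three numbers on record. Compound 1 `O=C(O)CC/C=C\CC1COC(c2cccc3ccccc23)OC1c1cccnc1` gives 631 nM, and compound 2 `CC(C)(Oc1ccccc1)C1OCC(C/C=C\CCC(=O)O)C(c2cccnc2)O1` gives 75.9 nM. Two measured steps frame the series: an 8.3-fold lower number from compound 1 to compound 2 (0.92 log units; beyond the scatter) and a 4.0-fold higher number from compound 2 to compound 3 (0.60 log units; beyond the scatter).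

Compound 4 `CC(C)(Sc1ccccc1)C1OCC(C/C=C\CCC(=O)O)C(c2cccnc2)O1` differs from compound 3 in one place: phenylsulfanyl in place of 4-methoxyphenoxy on a saturated chain carbon bound to two saturated chain carbons and a saturated ring carbon. One part of this change reverses the measured step from compound 2 to compound 3, since the methoxy on the aromatic carbon leaves; that step raised the number, so its removal should lower it again. Among the compounds with values here, the other part, the exchange of the oxygen linking the aromatic ring for sulfur, has no counterpart among the measured compounds, so nothing on record speaks to its size or direction.

Compound 4 is therefore expected to land near compound 2, with an estimated step of a 3.0-fold lower number from compound 3 to compound 4 (0.48 log units; beyond the scatter) in this assay. The estimate for compound 4 is 100 nM, within a range from 35 nM to 300 nM, the range widened for the untested sulfur swap.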

Compound 4, dissociation constant: 200 nM
Compound 4: middle estimate off by 2.0-fold (0.30 log units), on the low side; the range from low to high includes it.
By their numbers in this assay, from the lowest: compound 2; then compounds 4 and 3 (each within the scatter of the next); then compound 1.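

In this assay, within the data shown here, replacing phenoxy with phenylsulfanyl on this saturated chain carbon gives a 2.6-fold higher number from compound 2 to compound 4 (0.42 log units; beyond the scatter), so the step that exchanges the linking oxygen for sulfur, which no earlier pair isolated, is now measured and lies beyond the scatter. Against 4-methoxyphenoxy, the same group gives a 1.5-fold lower number from compound 3 to compound 4 (0.18 log units; within the scatter), which is within the scatter, so both changes from compound 2 raise the number, and the two resulting compounds cannot be told apart here. The phenylsulfanyl-bearing group also retains an advantage over the group of compound 1 on the saturated ring carbon, with a 3.2-fold lower number from compound 1 to compound 4 (0.50 log units; beyond the scatter).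

No evidence is at hand on what lies behind the difference between the oxygen and sulfur links. Still open, as far as these compounds go, is how an amine or a methylene link would read at this place, and whether methoxy on the aromatic ring of compound 4 would raise the number again.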